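Compound 2 to compound 3: a methylcarbamoyl swap

A few compounds are considered here, and "the series" means these few. Any claim that something is new, unique, unknown or untested is made for them only; others in the source may bear on it.

Compound 1 `COc1ccccc1-c1nc(-c2nc(C)n[nH]2)c(OC)c2ncccc12`: > 50100 nM (a limit)
Compound 2 `COc1ccccc1-c1nc(-c2nnc(C)o2)c(O)c2ncccc12`: > 50100 nM (a limit)

Both compounds were tested in a toxicity assay on THP-1 cells (Homo sapiens) for cytotoxicity; on this read-out lower numbers stand for an effect already at smaller amounts and higher numbers for an effect only at larger amounts of compound. Neither gave a number, and the record so far holds only (the limit of > 50100 nM in this assay, at which 2 of the 2 values shown sit). As far as these compounds go, compound 2 stands at that limit with > 50100 nM, so its true position remains open.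

Compound 3 `CNC(=O)c1nc(-c2ccccc2OC)c2cccnc2c1O` carries methylcarbamoyl in place of 5-methyl-1,3,4-oxadiazol-2-yl on an aromatic carbon, ortho to a hydroxy group and next to the ring nitrogen. Going by the values given here, no measured pair shows what such a change does. The expectation therefore rests on the two limits alone, and compound 3 is expected to stay at or near the same limit, with any movement going towards lower numbers. The estimated step of an at least 1.2-fold lower number from compound 2 to compound 3 (0.09 log units; that floor lies within the scatter) is expected to be small. In this assay the estimate for compound 3 is 40000 nM, expected within 12000 nM to 60000 nM.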

Compound 3, half-maximal effective concentration in the THP-1 assay: 39800 nM
Compound 3: the middle estimate sits 1.0-fold (0.00 log units) above what was measured, and the stated range covers the measured number.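

In the THP-1 assay compound 3 gives 39800 nM as a number rather than a limit, which shows that an effect can be read at this place once methylcarbamoyl stands in place of 5-methyl-1,3,4-oxadiazol-2-yl on the aromatic carbon. As far as these compounds go, the change reads as an at least 1.2-fold lower number from compound 2 to compound 3 (0.09 log units; that floor lies within the scatter), so only a floor on the step is known and its true size stays open. In a physicochemical assay for solubility, measured as kinetic solubility (a lower number here means a less soluble compound, a higher number a more soluble compound), compound 2 gives > 250000 nM as a limit of the assay. In the physicochemical assay compound 3 gives 219000 nM as a measured number. In the physicochemical assay the same change reads as an at least 1.1-fold lower number from compound 2 to compound 3 (0.05 log units; that floor lies within the scatter), again only a floor, with a measured number on one side and a limit on the other.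

The change removes a ring and brings in the amide hydrogen at once, and the compounds shown do not separate these two. They also leave open how a carboxylic acid or a dimethylcarbamoyl group would read at this place.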